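This account rests on a few compounds, and the source may have more. Where it says the series, first, only, none or still open, it means among the compounds named here.

Measured compounds:
compound 1, `C=CCSc1nncc2cnc(-c3ccccc3)n12` — > 48000 nM
compound 2, `CCCOc1ccccc1-c1ncc2cnnc(O)n12` — > 48000 nM
compound 3, `COc1ccc(-c2ncc3cnnc(O)n23)cc1` — > 48000 nM

In a functional assay for inhibition, with Homo sapiens as the target (on this read-out lower numbers stand for stronger inhibition and higher numbers for weaker inhibition), compound 1 reaches only the limit of the assay, > 48000 nM. Compound 2 likewise gives a limit, > 48000 nM. Compound 3 also gives a limit, > 48000 nM. Compound 3 therefore stands at the limit of > 48000 nM in this assay, at which 3 of the 3 values shown sit, and no numbered value among these three compounds exists to set it against; nothing can be said about an order among them.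

Compound 4, `Oc1nncc2cnc(-c3ccccc3)n12`, differs from compound 3 by hydrogen in place of methoxy on an aromatic carbon. Within the data shown here, no step between two measured compounds is available to guide the expectation for this change. The step from compound 3 to compound 4 in this assay is expected to be a step that the limit leaves unreadable from compound 3 to compound 4, none beyond the scatter, because the limit of > 48000 nM in this assay, at which 3 of the 3 values shown sit, leaves no room for a smaller number to be read from compound 3. Compound 4 is therefore expected to give about 60000 nM, within 20000 nM to 200000 nM, and most probably again only as a limit rather than a number.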

Compound 4, half-maximal inhibitory concentration: > 48000 nM
Compound 4: no number, only a limit (the forecaster's own chance of this, stated with the estimate: 85%); the middle value is on the limit's open side.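

No step can be read between compound 4 and compound 1, compound 2 or compound 3, because each of the four gives only a limit: the limit of > 48000 nM in this assay, at which 4 of the 4 values shown sit. The compounds shown leave open how strongly any of them inhibits and which change, if any, alters that.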